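The source may hold more compounds than are shown below. What is called first, only, known or untested is meant among the compounds shown, and "the series" means these compounds.

Compound 3 `COc1ccc(-c2cc(N3CCC(CNS(N)(=O)=O)CC3)ncn2)cc1` stands at the edge of what a functional assay on M21 cells (Homo sapiens) for antiproliferative activity, read by sulforhodamine B assay, with a stated time of 48 h (a lower number here means a stronger inhibitor of growth, a higher number a weaker inhibitor of growth), can report: in this assay compound 3 gives > 100000 nM, which is a limit and not a number (the limit of > 100000 nM in this assay, at which 1 of the 3 values shown sits). Its two measured neighbours share the same core. Compound 1 `Cc1ccc(-c2cc(N3CCC(CNS(N)(=O)=O)CC3)ncn2)cc1` gives 71000 nM in this assay, and compound 2 `CC(C)(C)c1ccc(-c2cc(N3CCC(CNS(N)(=O)=O)CC3)ncn2)cc1` gives 19300 nM. The step of an at least 1.4-fold higher number from compound 1 to compound 3 (0.14 log units; that floor lies within the scatter) stays within the scatter, so compound 1 and compound 3 cannot be ordered, while an at least 5.1-fold higher number from compound 2 to compound 3 (0.71 log units; beyond the scatter) and a 3.7-fold lower number from compound 1 to compound 2 (0.57 log units; beyond the scatter) both lie beyond it, placing compound 2 clearly ahead of the other two.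

The unmeasured compound 4 `NS(=O)(=O)NCC1CCN(c2cc(-c3ccc(Cl)cc3)ncn2)CC1` differs from compound 3 by chloro in place of methoxy on an aromatic carbon. Within the data shown here, none of the measured steps carries exactly this change; the nearest guidance is that the methoxy compound 3 sits at the limit while the methyl compound 1 and the tert-butyl compound 2 both give numbers. Compound 4 is therefore expected to leave the limit, a step of an at least 2.5-fold lower number from compound 3 to compound 4 (0.39 log units; beyond the scatter). The estimate for compound 4 in this assay is 40000 nM, with a range from 12000 nM to 150000 nM.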

Compound 4, concentration for 50% growth inhibition: 50300 nM
The estimate for compound 4 lay 1.3-fold (0.10 log units) below the measured number; the range from low to high includes it.
By their numbers in this assay, from the lowest: compound 2; then compounds 4 and 1 (each within the scatter of the next). At a limit, above all of these: compound 3.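

In this assay, chloro on this aromatic carbon, para to a large group, gives a measured number, and a 1.4-fold lower number from compound 1 to compound 4 (0.15 log units; within the scatter) stays within the scatter, so chloro and methyl cannot be ordered here. The larger tert-butyl group remains the one substituent clearly ahead: a 2.6-fold higher number from compound 2 to compound 4 (0.42 log units; beyond the scatter) places chloro behind it. For the change from 4-methoxyphenyl to 4-chlorophenyl itself, an at least 1.9-fold lower number from compound 3 to compound 4 (0.29 log units; that floor lies within the scatter) gives only a floor and no order, and the methoxy compound remains a limit and not a number: the limit of > 100000 nM in this assay, at which 1 of the 4 values shown sits.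

From the compounds shown here alone, whether an amine, a carboxylic acid or a longer alkyl chain at this position would match or pass tert-butyl stays open. All four compounds differ in this one place, so they say nothing about changes elsewhere on the shared core.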